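The source may report more compounds than this note shows. Statements on the series, on what has been measured and on what is new or still open speak of the compounds shown alone.

Measured compounds:
- Compound 1, `CCC1c2cc(Cl)ccc2C(=O)N1c1cccnc1`: in an ADME assay on microsomes from liver (Mus musculus) for metabolic stability, read by LC-MS, using NADPH, with stated times of 10 min and 30 min (on this read-out higher numbers stand for fast clearance and lower numbers for slow clearance), compound 1 gives 65.9 mL/min/kg
- Compound 2, `CC1c2cc(Cl)ccc2C(=O)N1c1cccnc1`: in this assay compound 2 gives 66.5 mL/min/kg
- Compound 3, `CCC(=O)N[C@@H]1CCCc2c1cncc2N1C(=O)c2ccc(Cl)cc2[C@H]1CC`: in this assay compound 3 gives 44.9 mL/min/kg

Compound 2 differs from compound 1 by one change, (hydrogen in place of methyl on a saturated chain carbon bound to a saturated ring carbon), and that change made a step of a 1.0-fold higher number from compound 1 to compound 2 (0.00 log units; within the scatter). Compound 3 carries a different core; how its core differs from that of compound 1 is not broken down here. Compound 4, `CCC(=O)N[C@@H]1CCCc2c1cncc2N1C(=O)c2ccc(Cl)cc2[C@H]1C`, has not yet been measured. It differs from compound 3 by hydrogen in place of methyl on a saturated chain carbon bound to a saturated ring carbon, the same change that led from compound 1 to compound 2, at the same place. Since the earlier step of a 1.0-fold higher number from compound 1 to compound 2 (0.00 log units; within the scatter) lay within the scatter, the step to compound 4 is expected to be of similar size, a 1.0-fold higher number from compound 3 to compound 4 (0.00 log units; within the scatter). Compound 4 is therefore estimated at 45 mL/min/kg, roughly between 25 mL/min/kg and 80 mL/min/kg.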

Compound 4, clearance: 45.6 mL/min/kg
Estimate against measurement, compound 4: 1.0-fold (0.01 log units) below, and the stated range covers the measured number.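

Replacing methyl with hydrogen on the saturated chain carbon, which turns ethyl into methyl, gives a 1.0-fold higher number from compound 3 to compound 4 (0.01 log units; within the scatter) in this assay, and this step matches the earlier one: the same change on two cores in this assay, a 1.0-fold higher number (0.00 log units; within the scatter) from compound 1 to compound 2 and a 1.0-fold higher number (0.01 log units; within the scatter) from compound 3 to compound 4, 1.0-fold (0.00 log units) apart, within the scatter of two such steps

On these two cores, then, the change carries over in the plain sense that neither step can be told from repeat-measurement noise. This does not show that the change would behave the same way on other cores, and with steps this small, it cannot reveal whether a larger effect would also transfer.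

The compounds shown leave open how clearance would respond to a longer chain such as propyl at this place. They also leave open the effect of an amine or a carboxylic acid there.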